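The source may hold more compounds than are shown below. What is called first, only, known or untested is meant among the compounds shown, and "the series" means these compounds.

Among the compounds with values here, compound 2 `OCCC(NC1CCN(CCCc2c[nH]c3ccc(-n4cnnc4)cc23)CC1)c1ccccc1` gives 100% in a functional assay on CHO cells for activation of 5-hydroxytryptamine receptor 1D (Homo sapiens), read by GTPgammaS binding (on this read-out higher numbers stand for larger maximal responses and lower numbers for smaller maximal responses), the highest of the two numbers so far. Compound 1 `c1cc(CNC2CCN(CCCc3c[nH]c4ccc(-n5cnnc5)cc34)CC2)co1` gives 65% in this assay, and the change was a number 35 percentage points higher from compound 1 to compound 2 (beyond the scatter), a swap of the group on the amine nitrogen. Compound 3 `CN(Cc1ccsc1)C1CCN(CCCc2c[nH]c3ccc(-n4cnnc4)cc23)CC1` carries methyl((thiophen-3-yl)methyl)amino in place of (3-hydroxy-1-phenylpropyl)amino on a saturated ring carbon. That single measured step bears on this change and was large; compound 1, with 65%, also carries a five-membered aromatic ring with 1 hetero atom on the same nitrogen, so a move back toward that level is expected, a number 30 percentage points lower from compound 2 to compound 3 (beyond the scatter). For compound 3 the expected efficacy in this assay is 70%, range 50% to 95%.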

Compound 3, largest response reached (reported as efficacy), in percent of the reference or control that the assay uses: 93%
Compound 3: the middle estimate sits 23 percentage points below what was measured; the range from low to high includes it.
By their numbers in this assay, from the lowest: compound 1; then compounds 3 and 2 (each within the scatter of the next).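

In this assay the high response does not depend on 3-hydroxy-1-phenylpropyl: the step of a number 7 percentage points lower from compound 2 to compound 3 (within the scatter) holds with an entering group that has no phenyl ring, no hydroxyl and no hydrogen-bond donors. The low level of compound 1 is also not shared by every five-membered aromatic ring on this ring carbon, as the step of a number 28 percentage points higher from compound 1 to compound 3 (beyond the scatter) shows. No measurement here gives a cause for either step.

On these data alone, the step from compound 1 to compound 3 changes both the ring and the methyl on nitrogen, so their shares remain open. Methyl((furan-3-yl)methyl)amino or ((thiophen-3-yl)methyl)amino would separate them.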